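Swapping the Aryl on the Saturated Ring Carbon

This account rests on a few compounds, and the source may have more. Where it says the series, first, only, none or still open, it means among the compounds named here.

Of the compounds shown here, three built on a shared core have been measured in an assay on cells for inhibition of histone deacetylase 4 (Homo sapiens), read by fluorescence, with a stated time of 30 min; on this read-out lower numbers stand for stronger inhibition and higher numbers for weaker inhibition. Compound 1 `O=C1NC(=O)/C(=C\c2ccc(OCC(=O)N3N=C(c4ccccc4)CC3c3ccccc3Cl)cc2)S1` gives 1200 nM. Compound 2 `O=C1NC(=O)/C(=C\c2ccc(OCC(=O)N3N=C(c4ccccc4)CC3c3ccc(Cl)c(Cl)c3)cc2)S1` gives 700 nM, and compound 3 `O=C1NC(=O)/C(=C\c2ccc(OCC(=O)N3N=C(c4ccc(F)cc4)CC3c3ccccc3Cl)cc2)S1` gives 1100 nM. Compound 3 thus stands second highest of the three numbers; the step of a 1.1-fold lower number from compound 1 to compound 3 (0.04 log units; within the scatter) lies within the scatter, and the values of compound 3 and compound 2 also sit within the scatter of each other.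

Compound 4 `O=C1NC(=O)/C(=C\c2ccc(OCC(=O)N3N=C(c4ccc(F)cc4)CC3c3ccc(F)cc3)cc2)S1` has not yet been measured. It differs from compound 3 in one place: 4-fluorophenyl in place of 2-chlorophenyl on a saturated ring carbon.

Going by the values given here, only one measured step alters the same saturated ring carbon, namely a 1.7-fold lower number from compound 1 to compound 2 (0.23 log units; within the scatter), and it stays within the scatter. The other step, a 1.1-fold lower number from compound 1 to compound 3 (0.04 log units; within the scatter), touches a different position and is likewise within the scatter. Nothing among these compounds therefore points to a movement in this assay beyond the scatter when 4-fluorophenyl replaces 2-chlorophenyl at that carbon. The expected step is a 1.1-fold lower number from compound 3 to compound 4 (0.04 log units; within the scatter), meaning no change of real size. For compound 4 in this assay the estimate is 1000 nM, with an expected range from 400 nM to 2500 nM.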

Compound 4, half-maximal inhibitory concentration: 1400 nM
The estimate for compound 4 lay 1.4-fold (0.15 log units) below the measured number; the measured number falls inside the stated range.
By their numbers in this assay, from the lowest: compounds 2, 3, 1 and 4 (each within the scatter of the next).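

In this assay, the second aryl change at this saturated ring carbon, a 1.3-fold higher number from compound 3 to compound 4 (0.10 log units; within the scatter), also stays within the scatter. Going by these compounds alone, until now the only change at this carbon was a 1.7-fold lower number from compound 1 to compound 2 (0.23 log units; within the scatter), made on the core of compound 1, so compound 4 extends the picture in two ways: to a different halogen on the incoming phenyl and to the core of compound 3, which carries the 4-fluorophenyl group at its other aryl position. Across these two single swaps at this carbon, none of the three aryl groups shown separates from the others beyond the scatter, and no compound here goes against that, although nothing available explains this tolerance.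

All three groups at this carbon are halogen-bearing phenyl rings, so the compounds shown leave open whether an amine, a carboxylic acid or a longer chain in that place would move the number beyond the scatter. They also leave open whether an unsubstituted phenyl at this carbon would fall within the same narrow band.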